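Aryl in place of vinyl on the chain carbon at the ring nitrogen

A few compounds are considered here, and "the series" means these few. Any claim that something is new, unique, unknown or untested is made for them only; others in the source may bear on it.

Three compounds of the series share one core and differ only in the group on the saturated chain carbon bound to an aromatic nitrogen. Compound 1 `COc1ccc([C@@H]2CC(=O)c3c(O)cc(OCc4cn(Cc5ccccc5F)nn4)cc3O2)cc1O` gives 7320 nM in a functional assay on RAW264.7 cells (Mus musculus) for inhibition, read by Griess assay, with stated times of 2 h and 24 h; a higher number here means a weaker inhibitor, a lower number a stronger inhibitor. Compound 2 `COc1ccc([C@@H]2CC(=O)c3c(O)cc(OCc4cn(Cc5ccccc5C#N)nn4)cc3O2)cc1O` gives 14600 nM in this assay, and compound 3 `C=CCn1cc(COc2cc(O)c3c(c2)O[C@H](c2ccc(OC)c(O)c2)CC3=O)nn1` gives 13800 nM in this assay. Compound 3 stands second highest of these three numbers, but all three lie within the scatter of one another: a 2.0-fold higher number from compound 1 to compound 2 (0.30 log units; within the scatter), a 1.9-fold higher number from compound 1 to compound 3 (0.28 log units; within the scatter), a 1.1-fold lower number from compound 2 to compound 3 (0.02 log units; within the scatter).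

Compound 4 `COc1ccc([C@@H]2CC(=O)c3c(O)cc(OCc4cn(Cc5ccc(Cl)cc5)nn4)cc3O2)cc1O` is not yet measured. It differs from compound 3 by 4-chlorophenyl in place of vinyl on a saturated chain carbon bound to an aromatic nitrogen; cut one bond further out, the change reads allyl to 4-chlorobenzyl. Among the compounds with values here, the steps that bear on it run in the opposite direction: a 1.9-fold higher number from compound 1 to compound 3 (0.28 log units; within the scatter) and a 1.1-fold lower number from compound 2 to compound 3 (0.02 log units; within the scatter) each replaced an aryl group with vinyl at the same place, and neither moved the number beyond the scatter. Within the data shown here, a chlorine on that ring appears in no measured compound, so its own contribution is unknown. The expected step is therefore a 1.5-fold lower number from compound 3 to compound 4 (0.19 log units; within the scatter), no change beyond the scatter, with a slight lean toward a lower number in this assay. The estimate for compound 4 in this assay is 9000 nM, with a range from 4000 nM to 20000 nM.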

Compound 4, half-maximal inhibitory concentration: 17800 nM
Estimate against measurement, compound 4: 2.0-fold (0.30 log units) below; low and high end bracket the measured number.
By their numbers in this assay, from the lowest: compounds 1, 3, 2 and 4 (each within the scatter of the next, the first and the last beyond it).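

In this assay, replacing vinyl with 4-chlorophenyl gives a 1.3-fold higher number from compound 3 to compound 4 (0.11 log units; within the scatter), and exchanging 2-cyanophenyl for 4-chlorophenyl gives a 1.2-fold higher number from compound 2 to compound 4 (0.09 log units; within the scatter), so among these compounds neither step separates the groups on the saturated chain carbon bound to an aromatic nitrogen. Within the data shown here, the one step here that clears the scatter is between two aryl groups, a 2.4-fold higher number from compound 1 to compound 4 (0.39 log units; beyond the scatter), which shows that this position can respond modestly to a change of aryl group, while compound 2 and compound 3 remain within the scatter of both compound 1 and compound 4. Nothing at hand accounts for this step.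

A 4-fluorophenyl or a 2-chlorophenyl group at this place would show whether the step from 2-fluorophenyl to 4-chlorophenyl follows the halogen or its place on the ring, since the two groups differ in both. On these data alone, how an amine, a carboxylic acid or a longer chain at this place would read in this assay also stays open.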